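Removing the Hydroxy from a Urea Side Chain

The compounds below may be only part of what the source reports. "The series", "measured", "known", "first", "only" and "open" are said of these compounds alone.

Measured so far:
compound 1 `O=C(NC1CCC(O)CC1)N1CCC(c2nc(-c3ccc4ccccc4n3)no2)CC1`: 2700 nM
compound 2 `O=C(NCC1CCC1)N1CCC(c2nc(-c3ccc4ccccc4n3)no2)CC1`: 410 nM

In a functional assay on Shh Light II cells (Mus musculus) for inhibition, read by a luciferase reporter (a lower number here means a stronger inhibitor, a higher number a weaker inhibitor), compound 1 gives 2700 nM, the higher of the two numbers measured. Compound 2 gives 410 nM. Going by the values given here, the only measured step, a 6.6-fold lower number from compound 1 to compound 2 (0.82 log units; beyond the scatter), exchanges the whole 4-hydroxycyclohexyl group for cyclobutylmethyl, so it removes the hydroxy together with a change of ring. Compound 3 `O=C(NC1CCCCC1)N1CCC(c2nc(-c3ccc4ccccc4n3)no2)CC1` is the unmeasured neighbour of compound 1; the change is hydrogen in place of hydroxy on a saturated ring carbon. That step bears on the question only in part, since the ring itself stays. Because the larger change a 6.6-fold lower number from compound 1 to compound 2 (0.82 log units; beyond the scatter) gave a modest drop, a smaller drop in this assay is expected here, in the same direction, though it may sit close to the scatter. Compound 3 is therefore estimated at 1000 nM, with a range from 350 nM to 2800 nM. The expected step is a 2.7-fold lower number from compound 1 to compound 3 (0.43 log units; beyond the scatter).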

Compound 3, half-maximal inhibitory concentration: 57 nM
Compound 3: the middle estimate sits 18-fold (1.24 log units) above what was measured, and the stated range ends above it.
By their numbers in this assay, from the lowest: compound 3; then compound 2; then compound 1.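

In this assay, the removal of the hydroxy alone, with the six-membered ring kept, gives a 47-fold lower number from compound 1 to compound 3 (1.68 log units; beyond the scatter), so this single change on a saturated ring carbon carries a large step that the earlier exchange of the whole side chain could not isolate. The ring also matters once the hydroxy is gone: the exchange of cyclobutylmethyl for cyclohexyl on the amide-type nitrogen gives a 7.2-fold lower number from compound 2 to compound 3 (0.86 log units; beyond the scatter), and neither group carries a hydroxy. Nothing available explains why either step has this size.

The compounds shown leave open whether another group on that ring carbon, such as a methoxy, an amine or a fluorine, would behave like hydroxy or like hydrogen. They also leave open how a cyclopentyl or cycloheptyl ring would compare with cyclohexyl.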